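Fluoro removal from compound 1: expected cytotoxicity

A few compounds are considered here, and "the series" means these few. Any claim that something is new, unique, unknown or untested is made for them only; others in the source may bear on it.

Measured so far:
compound 1, `CN(C)CCN1CCN(CC(=O)Nc2ccc(-c3nc4cc(F)ccc4o3)cc2)CC1`: 18800 nM
compound 2, `CN(C)CCCN1CCN(CC(=O)Nc2ccc(-c3nc4ccccc4o3)cc2)CC1`: 9500 nM

In a functional assay on HepG2 cells (Homo sapiens) for cytotoxicity, read by MTT assay, with a stated time of 24 h (a lower number here means a stronger inhibitor, a higher number a weaker inhibitor), compound 1 gives the higher of the two numbers, yet compound 2 sits within the scatter of it, so no order between them is claimed. Compound 3, `CN(C)CCN1CCN(CC(=O)Nc2ccc(-c3nc4ccccc4o3)cc2)CC1`, is not yet measured. It differs from compound 1 by hydrogen in place of fluoro on an aromatic carbon. Among the compounds with values here, no measured pair shows this change. Within the data shown here, since the two known numbers lie within the scatter of each other, the expected step is small: an estimated 1.3-fold lower number from compound 1 to compound 3 (0.13 log units; within the scatter), not beyond the scatter. Compound 3 is expected near 14000 nM, with a range of 7000 nM to 28000 nM.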

Compound 3, half-maximal inhibitory concentration: 16300 nM
The estimate for compound 3 lay 1.2-fold (0.07 log units) below the measured number; measured number inside the range.
By their numbers in this assay, from the lowest: compounds 2, 3 and 1 (each within the scatter of the next).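

In this assay the change from 5-fluoro-1,3-benzoxazol-2-yl to 1,3-benzoxazol-2-yl gives a 1.2-fold lower number from compound 1 to compound 3 (0.06 log units; within the scatter) and so shows no readable effect of removing fluoro at this position. The chain change also stays unresolved, with a 1.7-fold higher number from compound 2 to compound 3 (0.23 log units; within the scatter) for dimethylamino in place of (dimethylamino)methyl. Nothing available accounts for either result.

Still open, from the compounds shown here alone, is whether chloro or methoxy in place of fluoro would shift the number beyond the scatter. The same question applies to a chain longer than that of compound 2.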